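Oral mouse exposure: removing the methoxy from compound 1

The source may hold more compounds than are shown below. What is called first, only, known or untested is meant among the compounds shown, and "the series" means these compounds.

Compound 1 `CCCS(=O)(=O)Nc1ccc(Cl)c(C(=O)Nc2cnc3[nH]nc(OC)c3c2)c1F` gives 1080000 ng.h/mL in an ADME assay on the whole organism (plasma, strain CD-1) for pharmacokinetics, with Mus musculus as the target, at a dose of 30 mg/kg by the oral route (a lower number here means less compound in the circulation, a higher number more compound in the circulation at the dose given), the highest of the three numbers in hand. Compound 2 `CCCS(=O)(=O)Nc1ccc(F)c(C(=O)Nc2cnc3[nH]cc(Br)c3c2)c1F` gives 49000 ng.h/mL in this assay and compound 3 `CCCS(=O)(=O)Nc1ccc(F)c(C(=O)Nc2cnc3[nH]nc(C)c3c2)c1F` gives 18300 ng.h/mL, both below compound 1 by gaps beyond the scatter; each differs from compound 1 in more than one place, so no single change can be read from them. Compound 4 `CCCS(=O)(=O)Nc1ccc(Cl)c(C(=O)Nc2cnc3[nH]ncc3c2)c1F` is not yet measured. It differs from compound 1 by hydrogen in place of methoxy on an aromatic carbon, on an aromatic carbon of the five-membered aromatic ring with two nitrogen. Within the data shown here, no measured pair isolates this change. For compound 4 a step down of a 2.7-fold lower number from compound 1 to compound 4 (0.43 log units; beyond the scatter) is expected, likely near the edge of the scatter. Compound 4 is estimated at 400000 ng.h/mL, with a range from 100000 ng.h/mL to 1500000 ng.h/mL.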

Compound 4, area under the concentration-time curve in the Mus musculus assay: 147000 ng.h/mL
The estimate for compound 4 lay 2.7-fold (0.43 log units) above the measured number, within the range that was stated.
By their numbers in the Mus musculus assay, from the lowest: compound 3; then compound 2; then compound 4; then compound 1.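

Among these compounds, the first single-place step at this position, hydrogen in place of methoxy on an aromatic carbon, reads in the Mus musculus assay as a 7.3-fold lower number from compound 1 to compound 4 (0.87 log units; beyond the scatter). In a physicochemical assay for solubility, read by HPLC, in phosphate buffer, with a stated time of 24 h, at pH 6.5 (on this read-out lower numbers stand for lower solubility and higher numbers for higher solubility), compound 1 gives < 1 ug/mL, which is a limit of the assay and not a number. In the physicochemical assay compound 4 gives 15 ug/mL, so the same change moves the two read-outs in opposite directions: the measured solubility of compound 1, < 1 ug/mL, and of compound 4, 15 ug/mL, an at least 15-fold higher number (1.17 log units; beyond the scatter)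

One pair sets no pattern for this position. On these data alone, whether an amine or an ethoxy group on this carbon would keep the exposure of compound 1 while giving a solubility reading clear of the limit remains open.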